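Phenyl to Methyl on the Shared Core: Expected Cytotoxicity

A few compounds are considered here, and "the series" means these few. Any claim that something is new, unique, unknown or untested is made for them only; others in the source may bear on it.

Two compounds share one core and differ in a single group. Compound 1 `O=C1C(O)=C(C(c2ccc([N+](=O)[O-])cc2)c2c[nH]c3ccccc23)C(=O)c2ccccc21` carries hydrogen at that spot, while compound 2 `O=C1C(O)=C(C(c2ccc([N+](=O)[O-])cc2)c2c(-c3ccccc3)[nH]c3ccccc23)C(=O)c2ccccc21` carries phenyl there. In a functional assay on HeLa cells (Homo sapiens) for cytotoxicity, read by MTT assay, with a stated time of 48 h (on this read-out lower numbers stand for stronger inhibition and higher numbers for weaker inhibition), compound 1 gives 14800 nM, and compound 2 gives 6770 nM. Among the measured compounds shown here, compound 2 thus holds the lowest of the two numbers, with compound 1 as its only neighbour, and the step of a 2.2-fold lower number from compound 1 to compound 2 (0.34 log units; beyond the scatter) marks that gain. Compound 3 `Cc1[nH]c2ccccc2c1C(C1=C(O)C(=O)c2ccccc2C1=O)c1ccc([N+](=O)[O-])cc1` has not yet been measured. It differs from compound 2 by methyl in place of phenyl on an aromatic carbon, on an aromatic carbon of a five-membered aromatic ring with 1 nitrogen, next to the ring nitrogen. For the measured compounds named here, only the step from compound 1 to compound 2 bears on this change, and it shows phenyl doing modestly better than hydrogen. With methyl being neither hydrogen nor phenyl, compound 3 is expected to give roughly 10000 nM, between 5000 nM and 20000 nM. That estimate means a 1.5-fold higher number from compound 2 to compound 3 (0.17 log units; within the scatter), back toward the number of compound 1.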

Compound 3, half-maximal inhibitory concentration: 4570 nM
Compound 3: middle estimate off by 2.2-fold (0.34 log units), on the high side, and the stated range ends above it.
By their numbers in this assay, from the lowest: compounds 3 and 2 (each within the scatter of the next); then compound 1.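

In this assay, methyl in place of phenyl gives (a 1.5-fold lower number from compound 2 to compound 3 (0.17 log units; within the scatter)), so this change cannot be told apart from repeat-measurement noise, although methyl has 1 heavy atom and phenyl has 6. Methyl in place of hydrogen gives (a 3.2-fold lower number from compound 1 to compound 3 (0.51 log units; beyond the scatter)), so in these three compounds, a carbon group of either size at this position goes with a lower number than hydrogen does. Nothing available here explains why the position behaves this way.

The compounds shown leave open how a group of another kind, such as an amine, a carboxylic acid or a longer chain, would fare at this position. They also leave open whether the same pattern would hold on a core with a different group in place of the nitro-bearing phenyl.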